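Amino acid esters of a fluorinated nucleoside: half-life

The source may hold more compounds than are shown below. What is called first, only, known or untested is meant among the compounds shown, and "the series" means these compounds.

Three compounds were measured in an ADME assay on tissue (MDA-MB-231 cells, Homo sapiens) for pharmacokinetics; a higher number here means that the compound lasts longer, a lower number that the compound disappears faster:
compound 1, `N[C@@H](CC(=O)OC[C@H]1O[C@@H](n2cc(F)c(=O)[nH]c2=O)C[C@@H]1O)C(=O)O`, gave 0.185 h;
compound 2, `N[C@@H](CCC(=O)O[C@H]1C[C@H](n2cc(F)c(=O)[nH]c2=O)O[C@@H]1CO)C(=O)O`, gave 0.138 h;
compound 3, `N[C@@H](CCC(=O)OC[C@H]1O[C@@H](n2cc(F)c(=O)[nH]c2=O)C[C@@H]1O)C(=O)O`, gave 0.288 h.

Compound 2 has the lowest of the three numbers, but its gap to compound 1 lies within the scatter, and only compound 3 stands beyond it. Compound 2 and compound 3 contain the same atoms joined differently; the difference between the two cores is not broken down here.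

Compound 1 arises from compound 3 by amino(carboxy)methyl in place of 2-amino-2-carboxyethyl on a saturated chain carbon bound to a carbonyl carbon, and this step gave a 1.6-fold lower number from compound 3 to compound 1 (0.19 log units; within the scatter). Compound 4, `N[C@@H](CC(=O)O[C@H]1C[C@H](n2cc(F)c(=O)[nH]c2=O)O[C@@H]1CO)C(=O)O`, is not yet measured in this assay. It arises from compound 2 by amino(carboxy)methyl in place of 2-amino-2-carboxyethyl on a saturated chain carbon bound to a carbonyl carbon, the same change made on the core of compound 2 rather than that of compound 3.

Within the data shown here, since the one measured example of this change produced a step within the scatter, compound 4 is expected to show a similar small change, a 1.4-fold lower number from compound 2 to compound 4 (0.14 log units; within the scatter), landing near or somewhat under compound 2. The estimate for compound 4 in this assay is 0.1 h, with a range from 0.05 h to 0.2 h.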

Compound 4, half-life: 0.322 h
Beside the measured number, compound 4's estimate is 3.2-fold (0.51 log units) below it, outside the stated range (above it).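

In this assay, amino(carboxy)methyl in place of 2-amino-2-carboxyethyl on the core of compound 2 gave a 2.3-fold higher number from compound 2 to compound 4 (0.37 log units; beyond the scatter), a step beyond the scatter, unlike the step seen on the core of compound 3. The result of this change therefore did not carry from one core to the other in this series: the same change on two cores in this assay, a 1.6-fold lower number (0.19 log units; within the scatter) from compound 3 to compound 1 and a 2.3-fold higher number (0.37 log units; beyond the scatter) from compound 2 to compound 4, 3.6-fold (0.56 log units) apart, beyond the scatter of two such steps This does not show why the outcome depends on the core, and with a single pair on each core it cannot tell how the change would behave on any further core.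

The compounds shown leave open whether a longer chain would also give different steps on the two cores. They also leave open whether an amide in place of the ester, or the opposite configuration at the defined stereocentre of the amino acid part, would separate the two cores in the same way.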